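A few compounds are considered here, and "the series" means these few. Any claim that something is new, unique, unknown or untested is made for them only; others in the source may bear on it.

Within the data shown here, compound 1 `CNCc1ccc(Cl)c(-c2ccccc2OC)c1` is the only compound with a number here: in a functional assay on HEK293 cells for agonist activity at 5-hydroxytryptamine receptor 7 (Homo sapiens), read by a luciferase reporter and beta-arrestin recruitment, with a stated time of 22 h (on this read-out higher numbers stand for larger maximal responses and lower numbers for smaller maximal responses), compound 1 gives 61%. Compound 2 `CCNCc1ccc(Cl)c(-c2ccccc2OC)c1` is reported in this assay only as "not active" (no number reported), without a number. Compound 3 `CCN(CC)Cc1ccc(Cl)c(-c2ccccc2OC)c1` has not been measured. It differs from compound 1 by diethylamino in place of methylamino on a saturated chain carbon bound to an aromatic carbon. Among the measured compounds shown here, no step between measured compounds is given. Because compound 2 gives "not active" (no number reported) in this assay, compound 3 is expected to give a smaller maximal response, a step of a number 41 percentage points lower from compound 1 to compound 3 (beyond the scatter) beyond the scatter. The estimate for compound 3 in this assay is 20%, with a range from 0% to 50%.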

Compound 3, largest response reached (Emax), in percent of the reference or control that the assay uses: "not active" (no number reported)
Compound 3: no number reported; there is nothing to compare the estimate with.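

Among these compounds, compound 3, like compound 2, is reported without a number in this assay, and no step from compound 1 can be read. The compounds shown leave open how far the maximal responses of compound 2 and compound 3 lie from that of compound 1. No measurement shown bears on this result.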